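Rearranging the Chlorines of Compound 3

The source may report more compounds than this note shows. Statements on the series, on what has been measured and on what is new or still open speak of the compounds shown alone.

In a functional assay on NCI-H460 cells (Homo sapiens) for inhibition, read by MTT assay, with a stated time of 48 h (a higher number here means a weaker inhibitor, a lower number a stronger inhibitor), compound 1 (`O=C(CC(c1ccccc1)C(C(=O)Nc1ccccn1)C(=O)Nc1ccccn1)c1ccccc1`) is reported as "not active" (no number reported). Compound 2 (`O=C(CC(c1ccc(F)cc1)C(C(=O)Nc1ccccn1)C(=O)Nc1ccccn1)c1ccccc1`) is also reported as "not active" (no number reported). Compound 3 (`O=C(CC(c1ccc(Cl)cc1Cl)C(C(=O)Nc1ccccn1)C(=O)Nc1ccccn1)c1ccccc1`) gives 13100 nM, the only number among these three, so it has no other figure to be ranked against. Compound 4 (`O=C(CC(c1c(Cl)cccc1Cl)C(C(=O)Nc1ccccn1)C(=O)Nc1ccccn1)c1ccccc1`) awaits testing and carries 2,6-dichlorophenyl in place of 2,4-dichlorophenyl on a saturated chain carbon bound to two saturated chain carbons. Among the compounds with values here, no measured pair shows what such a change does, so the only anchor is compound 3 at 13100 nM. The expected step, a 1.1-fold higher number from compound 3 to compound 4 (0.03 log units; within the scatter), stays within the usual scatter of this assay, with no direction favoured. For compound 4 the estimated value is 14000 nM, with an expected range from 6000 nM to 35000 nM.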

Compound 4, half-maximal inhibitory concentration: 27400 nM
Estimate against measurement, compound 4: 2.0-fold (0.29 log units) below, within the range that was stated.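

Rearranging the chlorines at this position changes the result even though the atoms stay the same: in this assay the step is a 2.1-fold higher number from compound 3 to compound 4 (0.32 log units; beyond the scatter), a modest change. Among these two groups, 2,4-dichlorophenyl therefore gives the stronger inhibitor on this saturated chain carbon. Nothing available explains the difference.

The compounds shown leave open whether chlorine itself is needed on this ring. A methoxy group or a nitrile in place of the chlorines would help to test that.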